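Ethoxy to (3-bromobenzyl)amino on compound 3

The source may report more compounds than this note shows. Statements on the series, on what has been measured and on what is new or still open speak of the compounds shown alone.

In an ADME assay on HEK-293T cells (Homo sapiens) for cytotoxicity, read by luminescence, with a stated time of 24 h (a lower number here means that less compound is tolerated, a higher number that more compound is tolerated), compound 1 (`CCCNC(=O)c1cc2sccc2n1Cc1ccc(OC)cc1`) reads > 100000 nM as a limit of the assay. Compound 2 (`COc1ccc(Cn2c(C(=O)NCc3ccccc3)cc3sccc32)cc1`) reads > 100000 nM and this too is a limit. Within the data shown here, compound 3 (`CCOC(=O)C1CCN(C(=O)c2cc3sccc3n2Cc2ccc(OC)cc2)CC1`) gives 39000 nM as the only actual number in the set. The other two compounds stand at the limit of > 100000 nM in this assay, at which 2 of the 3 values shown sit, and offer no second number for comparison.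

Compound 4 (`COc1ccc(Cn2c(C(=O)N3CCC(C(=O)NCc4cccc(Br)c4)CC3)cc3sccc32)cc1`) keeps the rest of compound 3 and carries (3-bromobenzyl)amino in place of ethoxy on a carbonyl carbon.

Among the measured compounds shown here, only one measured step is available, a step that the two limits leave unreadable from compound 1 to compound 2 and it sits at a different place on a different parent. It brings in a phenyl, as the entering group here also does, but it supplies no size to carry over. For the measured compounds named here, no measured step therefore bears directly on this change, and the value of compound 3 remains the only anchor. No shift beyond the scatter is expected in this assay and neither direction is favoured. The expected change is a 1.3-fold lower number from compound 3 to compound 4 (0.11 log units; within the scatter) with wide uncertainty. Compound 4 is estimated at 30000 nM with an expected range of 10000 nM to 100000 nM in this assay.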

Compound 4, half-maximal cytotoxic concentration: > 100000 nM
Compound 4 was reported as a limit; the forecaster's own chance of this, stated with the estimate: 25%; middle value at least 3.3-fold (0.52 log units) from the limit.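

In this assay, (3-bromobenzyl)amino in place of ethoxy on a carbonyl carbon gives an at least 2.5-fold higher number from compound 3 to compound 4 (0.40 log units; beyond the scatter). Among these compounds, this is the only readable step in the set, as the step between compound 1 and compound 2 cannot be read, and it shows that the number responds to a change on this carbonyl carbon, with the ester of compound 3 giving way to an amide carrying a six-membered aromatic ring of carbon only. The step gives a lower bound and not a full size, and compound 4 adds no second actual number to the series: the limit of > 100000 nM in this assay, at which 3 of the 4 values shown sit.

The compounds shown leave open whether the step comes with the loss of ethoxy or with the entry of (3-bromobenzyl)amino, and whether the bromine has any part in it. A carboxylic acid or an unsubstituted benzylamino on the same carbonyl carbon would separate these readings, and any such comparison would need values that fall short of the limit.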